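The compounds below may be only part of what the source reports. "The series", "measured", "known", "first", "only" and "open" are said of these compounds alone.

Compounds measured so far in a functional assay on A498 cells (Homo sapiens) for inhibition, read by sulforhodamine B assay, with a stated time of 48 h, tested at 10 uM; a lower number here means a stronger effect, a higher number a weaker effect of the compound at the concentration tested:

compound 1, `COc1cc(Cl)cc(-c2nn(-c3cccc(NC(=O)Nc4ccc(Cl)c(C(F)(F)F)c4)c3)cc2-c2ccncc2)c1`: -9.18%
compound 2, `COc1cc(Cl)cc(-c2nn(-c3cccc(NC(=O)Nc4cccc(C(F)(F)F)c4)c3)cc2-c2ccncc2)c1`: -6.74%
compound 3, `COc1cc(Cl)cc(-c2nn(-c3cccc(NC(=O)c4cccc(C(F)(F)F)c4)c3)cc2-c2ccncc2)c1`: 21.2%

Compound 3 gives the highest number of the three, and both gaps to it lie beyond the scatter: a number 30.4 percentage points higher from compound 1 to compound 3 (beyond the scatter) and a number 27.9 percentage points higher from compound 2 to compound 3 (beyond the scatter). Both of those steps concern the group on the carbonyl carbon. Among the compounds with values here, the one change on the outer aromatic ring among the measured compounds, hydrogen in place of chloro, was small: a number 2.4 percentage points higher from compound 1 to compound 2 (within the scatter).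

Compound 4, `COc1cc(Cl)cc(-c2nn(-c3cccc(NC(=O)c4cc(C(F)(F)F)cc(C(F)(F)F)c4)c3)cc2-c2ccncc2)c1`, is compound 3 with a further change on that outer ring: trifluoromethyl in place of hydrogen on an aromatic carbon. Within the data shown here, no measured step adds a trifluoromethyl group to an aromatic carbon, so the only step that bears on it is the one from compound 1 to compound 2, which stayed within the scatter. Compound 4 is therefore expected to stay close to compound 3, with an estimated step of a number 1.2 percentage points lower from compound 3 to compound 4 (within the scatter) in this assay, not beyond the scatter. The estimate for compound 4 is 20%, within a range from 5% to 35%.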

Compound 4, a percentage reported as activity, at one concentration (the size of the read-out at that concentration, not a potency): -1.74%
For compound 4 the middle estimate is 21.7 percentage points above the measured one; the measured number lies below the stated range.
By their numbers in this assay, from the lowest: compounds 1, 2 and 4 (each within the scatter of the next); then compound 3.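

In this assay the outer ring of the amide compounds proved responsive to substitution: trifluoromethyl in place of hydrogen, on a carbon meta to the existing trifluoromethyl group, gave a number 22.9 percentage points lower from compound 3 to compound 4 (beyond the scatter) and thus a stronger effect at the concentration tested. Within the data shown here, the only earlier change on this ring, hydrogen in place of chloro in the urea compounds, gave a number 2.4 percentage points higher from compound 1 to compound 2 (within the scatter), so that step did not carry over to this different change at a different place on the ring. Nothing available explains why this change has so large an effect.

The compounds shown leave open whether a nitrile or an amine on the same carbon would shift the number as far as trifluoromethyl does. They also leave open whether a second trifluoromethyl group at this place would have any such effect on the urea compounds.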